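This account rests on a few compounds, and the source may have more. Where it says the series, first, only, none or still open, it means among the compounds named here.

In a functional assay on MCF7 cells (Homo sapiens) for inhibition, read by MTT assay, with a stated time of 2 days (a higher number here means a weaker inhibitor, a lower number a stronger inhibitor), compound 1 (`Oc1cccc(/C=C/c2ccccc2O)c1`) gives 20.1 ug/mL and compound 2 (`Oc1cccc(/C=C/c2cccc(O)c2)c1`) gives 21 ug/mL as its value, which stands level with compound 1 within the scatter. Compound 3 (`COc1cccc(/C=C/c2cccc(O)c2)c1`) differs from compound 2 by one change (methyl in place of hydrogen on an oxygen on an aromatic ring) that is methyl in place of hydrogen on an oxygen on an aromatic ring, hydroxy to methoxy. Among the measured compounds shown here, no step between measured compounds is available, so only a small move toward a lower number in this assay is expected, close to the scatter. The estimate puts the step at a 1.4-fold lower number from compound 2 to compound 3 (0.15 log units; within the scatter) for now. Compound 3 is estimated at 15 ug/mL with an expected range (6 ug/mL to 38 ug/mL).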

Compound 3, half-maximal inhibitory concentration: 13 ug/mL
The estimate for compound 3 lay 1.2-fold (0.06 log units) above the measured number, and the stated range covers the measured number.
By their numbers in this assay, from the lowest: compounds 3, 1 and 2 (each within the scatter of the next).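

In this assay, methyl in place of hydrogen on an oxygen on an aromatic ring gives a 1.6-fold lower number from compound 2 to compound 3 (0.21 log units; within the scatter). This oxygen therefore accepts a methyl without a step beyond the scatter, so for this one pair the hydrogen on it is not required to hold the number at the level of compound 2. Nothing available explains the size of this step. Still open, on these data alone, is whether a longer chain such as ethoxy on the same oxygen, or an amine or a carboxylic acid in place of the hydroxy, would stay level. Also open, as far as these compounds go, is whether the remaining hydroxy of compound 3 accepts the same methyl.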